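Compound 2 to compound 3: cyclopropyl for carboxymethyl

The compounds below may be only part of what the source reports. "The series", "measured", "known", "first", "only" and "open" are said of these compounds alone.

Going by the values given here, in a physicochemical assay for lipophilicity, at pH 7.4 (a lower number here means a more polar compound, a higher number a more lipophilic compound), compound 1 (`CCOc1cc2[nH]c(Cc3nn(CC(=O)N4CCOCC4)c(=O)c4ccccc34)nc2cc1Cl`) gives 3.32 as one of only two measured numbers. Compound 2 (`O=C(O)Cn1nc(CC(=O)Nc2ccc(OC(F)(F)F)c(Cl)c2)c2ccccc2c1=O`) gives 2.92 as the lower of the two, and the gap to compound 1 lies beyond the scatter. These two compounds differ in more than one place, so their gap cannot be read as the size of any single change.

Compound 3 (`O=C(Cc1nn(C2CC2)c(=O)c2ccccc12)Nc1ccc(OC(F)(F)F)c(Cl)c1`) follows from compound 2 with cyclopropyl in place of carboxymethyl on an aromatic nitrogen and with nothing else altered. Among the compounds with values here, no measured pair sizes this exchange, so the expectation rests on the structural change alone. An all-carbon group without a hydrogen-bond donor or acceptor enters where a group with both leaves. A clear rise in this assay is therefore expected, well beyond the scatter, though its size is uncertain. The estimated change is a number 1.28 log units higher from compound 2 to compound 3 (beyond the scatter) in the upward direction. The estimate for compound 3 is 4.2 with an expected range from 3.6 to 4.8 around it.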

Compound 3, distribution coefficient: 5.43
Compound 3: middle estimate off by 1.23 log units, on the low side, and the stated range ends below it.
By their numbers in this assay, from the lowest: compound 2; then compound 1; then compound 3.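

In this assay, going by these compounds alone, cyclopropyl in place of carboxymethyl on the aromatic nitrogen gives a number 2.51 log units higher from compound 2 to compound 3 (beyond the scatter), the first step that can be assigned to one place, and it marks this position as one where a single exchange can move the read-out by a large amount. Nothing else in the structure differs across this step, so the whole difference belongs to the exchange, in which carboxymethyl, with its counted hydrogen-bond donor and acceptor, leaves and cyclopropyl, a three-membered ring of carbon only with neither, enters. No measurement available here ties the size of the step to any particular feature of either group.

This single step cannot separate the loss of carboxymethyl from the gain of cyclopropyl, and a methyl group, a longer alkyl chain or an amine on the same aromatic nitrogen would show how the read-out moves between these two groups. On these data alone, whether an exchange at this position gives a step of similar size on the core of compound 1 also remains open.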